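This account rests on a few compounds, and the source may have more. Where it says the series, first, only, none or still open, it means among the compounds named here.

Compound 3 `O=C(NCC(=O)N1[C@@H](c2cccc(O)c2)CC[C@H]1C(=O)O)[C@@H](S)Cc1ccc(O)cc1` gives 1.6 nM in an assay on isolated protein for inhibition of Neprilysin (Oryctolagus cuniculus) (on this read-out higher numbers stand for weaker inhibition and lower numbers for stronger inhibition), the lowest of the three numbers. Compound 1 `O=C(NCC(=O)N1[C@@H](c2cccc(O)c2)CC[C@H]1C(=O)O)[C@@H](S)Cc1ccccc1` gives 2.4 nM; the step of a 1.5-fold lower number from compound 1 to compound 3 (0.18 log units; within the scatter) lies within the scatter. Compound 2 `Cc1ccc([C@H]2CC[C@@H](C(=O)O)N2C(=O)CNC(=O)[C@@H](S)Cc2ccc(O)cc2)cc1` gives 5.5 nM, and the step of a 3.4-fold lower number from compound 2 to compound 3 (0.54 log units; beyond the scatter) is the only one beyond the scatter. Compound 4 `O=C(NCC(=O)N1[C@@H](c2cccc(O)c2)CC[C@H]1C(=O)O)C(S)Cc1ccc(F)cc1` carries a group of 10 heavy atoms (8 carbon, 1 fluorine, 1 sulfur; one six-membered aromatic ring of carbon only) in place of a group of 10 heavy atoms (8 carbon, 1 oxygen, 1 sulfur; one six-membered aromatic ring of carbon only), on a carbonyl carbon, that is a group of 10 heavy atoms (8 carbon, 1 fluorine, 1 sulfur) in place of one of 10 heavy atoms (8 carbon, 1 oxygen, 1 sulfur), on a carbonyl carbon whose other neighbour is an amide-type nitrogen. Within the data shown here, the step of a 1.5-fold lower number from compound 1 to compound 3 (0.18 log units; within the scatter) bears on it, as the hydroxy added there is removed here; the fluorine has no measured counterpart. No step beyond the scatter is expected, a 1.6-fold higher number from compound 3 to compound 4 (0.19 log units; within the scatter). Compound 4 is estimated at 2.5 nM, in the range 1 nM to 7 nM.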

Compound 4, half-maximal inhibitory concentration: 5.3 nM
The estimate for compound 4 lay 2.1-fold (0.33 log units) below the measured number, and the stated range covers the measured number.
By their numbers in this assay, from the lowest: compounds 3 and 1 (each within the scatter of the next); then compounds 4 and 2 (each within the scatter of the next).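

The group on the carbonyl carbon is not indifferent to its aromatic substituent: fluorine gives a 3.3-fold higher number from compound 3 to compound 4 (0.52 log units; beyond the scatter) and a 2.2-fold higher number from compound 1 to compound 4 (0.34 log units; beyond the scatter), whereas the earlier hydroxy-for-hydrogen step stayed within the scatter. The entering group has no defined stereocentre and the leaving group has one, so these steps do not isolate the fluorine. No measurement shown accounts for the shift.

Open, as far as these compounds go, is how the fluorine group behaves with its stereocentre defined. Also open, from the compounds shown here alone, is how chlorine, methoxy or an amine on that aromatic ring would compare.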